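This account rests on a few compounds, and the source may have more. Where it says the series, first, only, none or still open, it means among the compounds named here.

Compound 1 `O=[N+]([O-])c1ccc(S(=O)(=O)N2CC(n3cnc4c(Cl)nc(Cl)nc43)OCc3ccccc32)cc1` is one of three compounds tested in a functional assay on MCF7 cells (Homo sapiens) for cytotoxicity, read by sulforhodamine B assay, with a stated time of 3 days (on this read-out lower numbers stand for stronger inhibition and higher numbers for weaker inhibition), and in this assay compound 1 gives 355 nM. Among the three numbers it stands second highest. Nearest is compound 3 `O=[N+]([O-])c1ccc(S(=O)(=O)N2C[C@H](n3cnc4c(Cl)nc(Cl)nc43)OCc3ccccc32)cc1`, which in this assay gives 190 nM; the two share every atom and bond and differ only in whether the stereocentre is drawn with a configuration (the fact that one of compounds 1 and 3 is drawn with a defined configuration and the other without, at the place where they differ). That step is a 1.9-fold lower number from compound 1 to compound 3 (0.27 log units; within the scatter). Furthest is compound 2 `O=S(=O)(c1ccccc1NO)N1CC(n2cnc3c(Cl)nc(Cl)nc32)OCc2ccccc21`, which in this assay gives 1530 nM. That step, a 4.3-fold higher number from compound 1 to compound 2 (0.63 log units; beyond the scatter), comes from 2-(hydroxyamino)phenyl in place of 4-nitrophenyl on the sulfonyl sulfur.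

Compound 4 `O=[N+]([O-])c1ccc(S(=O)(=O)N2CC(n3cnc4c(Br)ncnc43)OCc3ccccc32)cc1` is not yet measured. It differs from compound 1 on a saturated ring carbon of the seven-membered non-aromatic ring: a group of 10 heavy atoms (5 carbon, 4 nitrogen, 1 bromine; one five-membered aromatic ring with 2 hetero atoms, one six-membered aromatic ring with 2 hetero atoms) in place of a group of 11 heavy atoms (5 carbon, 4 nitrogen, 2 chlorine; one five-membered aromatic ring with 2 hetero atoms, one six-membered aromatic ring with 2 hetero atoms), on a saturated ring carbon. Neither measured step touches that part of the molecule, since one changes the group on the sulfonyl sulfur and the other only the drawn configuration, so no step beyond the scatter is expected, with a wide range left open. Compound 4 is estimated at 450 nM, between 130 nM and 1600 nM, which means an expected step of a 1.3-fold higher number from compound 1 to compound 4 (0.10 log units; within the scatter).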

Compound 4, half-maximal inhibitory concentration: 1230 nM
Compound 4: the middle estimate sits 2.7-fold (0.44 log units) below what was measured; the measured number falls inside the stated range.
By their numbers in this assay, from the lowest: compounds 3 and 1 (each within the scatter of the next); then compounds 4 and 2 (each within the scatter of the next).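

The group on the saturated ring carbon next to the ring oxygen turns out to matter in this assay: with the group of one bromine in place of the group of two chlorine, the result is a 3.5-fold higher number from compound 1 to compound 4 (0.54 log units; beyond the scatter). Within the data shown here, the earlier steps changed only the group on the sulfonyl sulfur and the drawn configuration, so this is the first sign that the number also responds at this place, and it rises beyond the scatter. Nothing measured on these compounds explains the rise, and no available evidence bears on this step.

The step changes both the number and the kind of halogen at once, so the compounds shown cannot separate the loss of one halogen from the swap of chlorine for bromine. As far as these compounds go, a single chlorine or an amine on the same group would help to tell these apart, and the effect of either remains open.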